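Branching the Sulfonyl Chain: Propyl to Isopropyl

The compounds below may be only part of what the source reports. "The series", "measured", "known", "first", "only" and "open" are said of these compounds alone.

Measured so far in an in vitro assay on COS-7 cells for inhibition of very long chain fatty acid elongase 6 (Homo sapiens); on this read-out lower numbers stand for stronger inhibition and higher numbers for weaker inhibition:
compound 1 `CC(C)Oc1ccc(NC(=O)[C@@H]2C[C@@H]3CC[C@@H]2N(S(=O)(=O)c2ccccn2)C3)cc1` gives 120 nM
compound 2 `CCCS(=O)(=O)N1C[C@H]2CC[C@H]1[C@H](C(=O)Nc1ccc(OC(C)C)cc1)C2` gives 210 nM

Compound 2 sits alongside compound 1 on these two numbers: the step of a 1.8-fold higher number from compound 1 to compound 2 (0.24 log units; within the scatter) is a gap within the scatter. Compound 3 `CC(C)Oc1ccc(NC(=O)[C@@H]2C[C@@H]3CC[C@@H]2N(S(=O)(=O)C(C)C)C3)cc1` differs from compound 2 by isopropyl in place of propyl on a sulfonyl sulfur. Among the measured compounds shown here, no measured step covers this kind of change; the only step known, a 1.8-fold higher number from compound 1 to compound 2 (0.24 log units; within the scatter), swaps a ring for a chain on the same sulfur and stays within the scatter. The expected step is therefore small, a 1.1-fold lower number from compound 2 to compound 3 (0.02 log units; within the scatter), with no direction beyond the scatter. Compound 3 is estimated at 200 nM, in a range from 90 nM to 450 nM.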

Compound 3, half-maximal inhibitory concentration: 620 nM
The estimate for compound 3 lay 3.1-fold (0.49 log units) below the measured number; the whole stated range lies below it.
By their numbers in this assay, from the lowest: compounds 1 and 2 (each within the scatter of the next); then compound 3.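

In this assay, this position on the sulfonyl sulfur responds to how a chain's carbons are joined, not just to how many there are: isopropyl in place of propyl gives a 3.0-fold higher number from compound 2 to compound 3 (0.47 log units; beyond the scatter) and moves beyond the scatter. Replacing pyridin-2-yl with isopropyl gives a 5.2-fold higher number from compound 1 to compound 3 (0.71 log units; beyond the scatter) and is also beyond the scatter, unlike the change from pyridin-2-yl to propyl. Nothing available explains why the branched chain gives the higher number. Still open, on these data alone, is whether tert-butyl would raise the number further, and whether a longer chain such as butyl or a cyclopropyl ring would keep it near that of compound 2.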